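The compounds below may be only part of what the source reports. "The series", "measured", "known", "first", "only" and "open" are said of these compounds alone.

Measured so far in a functional assay on MDA-MB-231 cells (Homo sapiens) for antiproliferative activity, read by CCK-8 assay, with a stated time of 48 h; a higher number here means a weaker inhibitor, a lower number a stronger inhibitor:
- compound 1 `O=C(/C=C/CNCCOc1ccc(Oc2c(-c3ccc(F)cc3)sc3cc(O)ccc23)cc1)N1CCCC1`: > 50000 nM, a limit of the assay
- compound 2 `C/C=C/C(=O)NCCOc1ccc(Oc2c(-c3ccc(F)cc3)sc3cc(O)ccc23)cc1`: > 50000 nM, a limit of the assay

Compound 2 therefore has no exact number, and all that can be said of the pair is the limit of > 50000 nM in this assay, at which 2 of the 2 values shown sit. Compound 3 `O=C(/C=C/CNCCOc1ccc(Oc2c(-c3ccc(F)cc3)sc3cc(O)ccc23)cc1)N1CCC1` has 3-((azetidin-1-yl)carbonyl)prop-2-en-1-yl in place of (prop-1-en-1-yl)carbonyl on an amine nitrogen.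

Among the measured compounds shown here, only one measured step bears on this change: a step that the two limits leave unreadable from compound 1 to compound 2. It exchanges the same leaving group with 3-((pyrrolidin-1-yl)carbonyl)prop-2-en-1-yl, whose name differs from the entering group only in its ring. That step has no readable size, so it offers no number to carry over.

Compound 1, which carries that related group, also gives a limit of > 50000 nM. The expectation is therefore for no change beyond the usual scatter, with a number no higher from compound 2 to compound 3 (the limit leaves the size open) as the expected step. Compound 3 is estimated at 50000 nM, with an expected range from 25000 nM to 100000 nM, and it may well be reported only as a limit.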

Compound 3, half-maximal inhibitory concentration: > 50000 nM
Compound 3 gave a limit, no number (the forecaster's own chance of this, stated with the estimate: 85%); the middle value lies on the limit itself.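

No step can be read among compound 1, compound 2 and compound 3, since each result in this assay is a limit and not a number: the limit of > 50000 nM in this assay, at which 3 of the 3 values shown sit.

The compounds shown leave open how active each one actually is in this assay, and whether exchanging pyrrolidin-1-yl for azetidin-1-yl, or either side chain for (prop-1-en-1-yl)carbonyl, changes that activity at all.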